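Dropping a Chloro Group from Two Related Cores

This account rests on a few compounds, and the source may have more. Where it says the series, first, only, none or still open, it means among the compounds named here.

Measured compounds:
compound 1 `ClCc1ccccc1Cn1cnc2c(Cl)nc(Cl)nc21`: 4670 nM
compound 2 `ClCc1ccccc1Cn1cnc2c(Cl)ncnc21`: 25700 nM
compound 3 `ClCc1ccc(Cn2cnc3nc(Cl)nc(Cl)c32)cc1`: 4070 nM

All three were tested in a functional assay on A549 cells (Homo sapiens) for cytotoxicity, read by sulforhodamine B assay, with a stated time of 48 h; on this read-out lower numbers stand for stronger inhibition of growth and higher numbers for weaker inhibition of growth. Compound 1 and compound 2 share one core; the difference between that core and the core of compound 3 is not broken down here. In the first pair, the change hydrogen in place of chloro on an aromatic carbon gave a 5.5-fold higher number from compound 1 to compound 2 (0.74 log units; beyond the scatter), a weakening of growth inhibition. Compound 4 `ClCc1ccc(Cn2cnc3ncnc(Cl)c32)cc1` is not yet measured and is related to compound 3 by hydrogen in place of chloro on an aromatic carbon, the same change made at the same kind of place. For the measured compounds named here, since only one earlier example exists, the expectation rests on it alone: compound 4 is expected to show a step of about a 5.4-fold higher number from compound 3 to compound 4 (0.73 log units; beyond the scatter), because the earlier step of a 5.5-fold higher number from compound 1 to compound 2 (0.74 log units; beyond the scatter) was clearly beyond the scatter. Compound 4 is thus estimated at 22000 nM, with a likely range from 9000 nM to 55000 nM.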

Compound 4, concentration for total growth inhibition: 4160 nM
The estimate for compound 4 lay 5.3-fold (0.72 log units) above the measured number, outside the stated range (below it).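

In this assay, hydrogen in place of chloro gave a 1.0-fold higher number from compound 3 to compound 4 (0.01 log units; within the scatter), so on this core the change made no difference that can be told from the scatter. The effect seen on the first core therefore did not carry over to the second: the same change on two cores in this assay, a 5.5-fold higher number (0.74 log units; beyond the scatter) from compound 1 to compound 2 and a 1.0-fold higher number (0.01 log units; within the scatter) from compound 3 to compound 4, 5.4-fold (0.73 log units) apart, beyond the scatter of two such steps. For the compounds shown here, with only two cores, this shows that one core's result cannot safely be assumed for the other, but it does not show which structural difference between them is responsible or how the change would behave on a third core.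

The compounds shown leave open how another group in this place, such as an amine or a methoxy group, would affect growth inhibition on either core. They also leave open whether the two cores would diverge in the same way in other cell lines.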